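From 3-chlorophenyl to 1H-indol-6-yl

The source may hold more compounds than are shown below. What is called first, only, known or untested is meant among the compounds shown, and "the series" means these compounds.

Measured in a functional assay on U-251 cells (Homo sapiens) for antiproliferative activity, read by MTT assay, with a stated time of 48 h; a higher number here means a weaker inhibitor, a lower number a stronger inhibitor:
- compound 1 `COc1ccc(-c2nc3cccc(-c4cc(OC)c(OC)c(OC)c4)c3o2)cc1`: > 25000 nM
- compound 2 `COc1cc(-c2cccc3nc(-c4cccc(Br)c4)oc23)cc(OC)c1OC`: 6800 nM
- compound 3 `COc1cc(-c2cccc3nc(-c4cccc(Cl)c4)oc23)cc(OC)c1OC`: 18500 nM

Compound 1 gives only a limit, > 25000 nM, and not a number. Of the two real numbers, compound 3 has the higher one, 18500 nM, so it is the weaker of that pair. Compound 4 `COc1cc(-c2cccc3nc(-c4ccc5cc[nH]c5c4)oc23)cc(OC)c1OC` has 1H-indol-6-yl in place of 3-chlorophenyl on an aromatic carbon. Changes to this same group gave an at least 3.6-fold lower number from compound 1 to compound 2 (0.56 log units; beyond the scatter), an at least 1.3-fold lower number from compound 1 to compound 3 (0.13 log units; that floor lies within the scatter) and a 2.7-fold higher number from compound 2 to compound 3 (0.43 log units; beyond the scatter). Among the compounds with values here, these steps are modest, so a modest fall in the number is expected in this assay, though no measured compound carries this group. That means an expected 2.3-fold lower number from compound 3 to compound 4 (0.36 log units; beyond the scatter). The estimate for compound 4 is 8000 nM, with an expected range of 2000 nM to 24000 nM.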

Compound 4, half-maximal inhibitory concentration: 300 nM
The estimate for compound 4 lay 27-fold (1.43 log units) above the measured number; measured number below the stated range.
By their numbers in this assay, from the lowest: compound 4; then compound 2; then compound 3. At a limit, above all of these: compound 1.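

In this assay, the single-ring groups at this position, next to the ring nitrogen and the ring oxygen, had differed only modestly, but 1H-indol-6-yl gives a 62-fold lower number from compound 3 to compound 4 (1.79 log units; beyond the scatter) and a 23-fold lower number from compound 2 to compound 4 (1.36 log units; beyond the scatter). This position can therefore change activity far more than swapping one halogen for another suggested. The step of an at least 83-fold lower number from compound 1 to compound 4 (1.92 log units; beyond the scatter) is only a floor, as compound 1 gives a limit and not a number: the limit of > 25000 nM in this assay, at which 1 of the 4 values shown sits.

The compounds shown leave open whether the gain depends on the second ring or on the hydrogen on the ring nitrogen. Going by these compounds, how an amine or a carboxylic acid would behave at this position also remains open.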